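Adding a hydroxyoxetane to a pyrazole on a second core

This account rests on a few compounds, and the source may have more. Where it says the series, first, only, none or still open, it means among the compounds named here.

Three compounds share a common scaffold and differ only in the pyrazole ring attached through a nitrogen atom. Compound 1 `Cc1c(Nc2nc(N)c3c(C#N)c(N4CCC[C@H]4C)n(C)c3n2)cnn1C` gives 310 nM in an assay on HEK293 cells for inhibition of Leucine-rich repeat serine/threonine-protein kinase 2 (Homo sapiens), with a stated time of 48 h; on this read-out higher numbers stand for weaker inhibition and lower numbers for stronger inhibition. Compound 2 `Cc1c(Nc2nc(N)c3c(C#N)c(N4CCC[C@H]4C)n(C)c3n2)cnn1CC1(O)COC1` gives 220 nM in this assay, and compound 3 `Cc1nn(C)cc1Nc1nc(N)c2c(C#N)c(N3CCC[C@H]3C)n(C)c2n1` gives 190 nM.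

The change from compound 1 to compound 2 is 3-hydroxyoxetan-3-yl in place of hydrogen on a saturated chain carbon bound to an aromatic nitrogen; it produced a 1.4-fold lower number from compound 1 to compound 2 (0.15 log units; within the scatter). Compound 3 carries a different arrangement of the same atoms: 1,3-dimethyl-1H-pyrazol-4-yl in place of 1,5-dimethyl-1H-pyrazol-4-yl on a nitrogen on an aromatic ring. That change gave a 1.6-fold lower number from compound 1 to compound 3 (0.21 log units; within the scatter), so the two cores behave alike within the usual variation of this measurement.

Compound 4 `Cc1nn(CC2(O)COC2)cc1Nc1nc(N)c2c(C#N)c(N3CCC[C@H]3C)n(C)c2n1` has not yet been measured. It is built from compound 3 by 3-hydroxyoxetan-3-yl in place of hydrogen on a saturated chain carbon bound to an aromatic nitrogen, and the place where the new group enters is described in the same words as for the change from compound 1 to compound 2, so the two changes are the same change made on two closely related cores.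

The step from compound 3 to compound 4 in this assay is estimated as a 1.3-fold lower number from compound 3 to compound 4 (0.10 log units; within the scatter), set beside the earlier 1.4-fold lower number from compound 1 to compound 2 (0.15 log units; within the scatter). This expectation rests on the small earlier step and on compound 3 giving 190 nM with a core that tracked compound 1 closely. Compound 4 is expected to give about 150 nM, with a plausible range from 60 nM to 400 nM.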

Compound 4, half-maximal inhibitory concentration: 410 nM
Compound 4: middle estimate off by 2.7-fold (0.44 log units), on the low side; the whole stated range lies below it.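

In this assay, adding 3-hydroxyoxetan-3-yl on a saturated chain carbon bound to an aromatic nitrogen gave a 2.2-fold higher number from compound 3 to compound 4 (0.33 log units; beyond the scatter), a modest weakening of inhibition on this core, while the same addition on the core of compound 1 gave a 1.4-fold lower number from compound 1 to compound 2 (0.15 log units; within the scatter), a step that stays within the scatter. The change therefore did not carry over from one core to the other with the same effect, and the gap between the two steps is larger than repeated measurements would explain: the same change on two cores in this assay, a 1.4-fold lower number (0.15 log units; within the scatter) from compound 1 to compound 2 and a 2.2-fold higher number (0.33 log units; beyond the scatter) from compound 3 to compound 4, 3.0-fold (0.48 log units) apart, beyond the scatter of two such steps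

Among these compounds, this does not show why the two cores respond differently, since each core supplies only a single pair of compounds, and two pairs cannot establish a rule for the whole series. It does show that a small, harmless step on one core was a poor guide to the step on a closely related one, even though the two cores differ only in 1,3-dimethyl-1H-pyrazol-4-yl against 1,5-dimethyl-1H-pyrazol-4-yl.

The compounds shown leave open whether the gap belongs to the hydroxyoxetane itself or would also appear with another group in its place, such as a plain hydroxyethyl chain or a longer chain ending in an amine. They also leave open whether the same gap between these two pyrazoles would return with a different amine in place of the methylpyrrolidine on the shared core.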